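Phenylsulfonyl for 3-chlorobenzyl: one step carried to a second core

The source may hold more compounds than are shown below. What is called first, only, known or untested is meant among the compounds shown, and "the series" means these compounds.

Three compounds of this set have been run in an assay on HEK293 cells for displacement of a labelled ligand from 5-hydroxytryptamine receptor 6 (Homo sapiens), read by scintillation counting, with a stated time of 1 h; a lower number here means a stronger inhibitor, a higher number a weaker inhibitor. Compound 1 `C#CCNC1CCc2c(OCCCCCN3CCN(c4cccc5c4ccn5Cc4cccc(Cl)c4)CC3)cccc21` gives 223 nM. Among the measured compounds shown here, compound 2 `C#CCNC1CCc2c(OCCCCCN3CCN(c4cccc5c4ccn5S(=O)(=O)c4ccccc4)CC3)cccc21` carries phenylsulfonyl in place of 3-chlorobenzyl on an aromatic nitrogen, and compound 2 gives 51 nM; the step is a 4.4-fold lower number from compound 1 to compound 2 (0.64 log units; beyond the scatter), the only change in the set measured on both sides. Compound 3 `C#CCN(C)Cc1ccc(OCCCCCN2CCN(c3cccc4c3ccn4Cc3cccc(Cl)c3)CC2)cc1` gives 140 nM in this assay; its number sits within the scatter of compound 1 and is beyond the scatter away from compound 2. How the core of compound 3 differs from the core of compound 1 is not broken down here.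

Compound 4 `C#CCN(C)Cc1ccc(OCCCCCN2CCN(c3cccc4c3ccn4S(=O)(=O)c3ccccc3)CC2)cc1` has not yet been measured. It stands to compound 3 as compound 2 stands to compound 1: phenylsulfonyl in place of 3-chlorobenzyl on an aromatic nitrogen, at the same place in both pairs, so this is the same change made a second time, on a different core. For the measured compounds named here, the expected step in this assay is a 4.0-fold lower number from compound 3 to compound 4 (0.60 log units; beyond the scatter), set close to the measured one because a 4.4-fold lower number from compound 1 to compound 2 (0.64 log units; beyond the scatter) is the only measurement of this change available, while the untested core of compound 3 argues for leaving room on either side. Compound 4 is therefore expected to give about 35 nM in this assay, with a range from 12 nM to 100 nM that allows for the core difference and for a single supporting pair.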

Compound 4, inhibition constant: 38 nM
Estimate against measurement, compound 4: 1.1-fold (0.04 log units) below; the measured number falls inside the stated range.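

Read in this assay, phenylsulfonyl in place of 3-chlorobenzyl on the aromatic nitrogen gives a 3.7-fold lower number from compound 3 to compound 4 (0.57 log units; beyond the scatter), so the step seen on the core of compound 1 recurs at a matching size on the second core: the same change on two cores in this assay, a 4.4-fold lower number (0.64 log units; beyond the scatter) from compound 1 to compound 2 and a 3.7-fold lower number (0.57 log units; beyond the scatter) from compound 3 to compound 4, 1.2-fold (0.07 log units) apart, within the scatter of two such steps

For this change, the difference between the two cores therefore leaves no detectable mark on the size of the step, and the step can reasonably be treated as transferable between these two cores in this assay. Among the compounds shown here, this rests on only two matched pairs, however, and does not establish a general rule for the series or predict the step on a third core. Nor does it explain why the step has this size, and the swap of one group for the other cannot be assigned to any single feature of phenylsulfonyl.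

For the compounds shown here, still open is whether a similar step would appear with another group on the aromatic nitrogen, such as methylsulfonyl or benzoyl, or with a shorter or longer chain in place of the one shared by these compounds. Also open, from the compounds shown here alone, is whether the step holds for a secondary or tertiary amine other than those in compound 1 and compound 3, or at receptors other than this one.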